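(Bromomethyl)carbonyl in Place of Hydrogen on a Ring Nitrogen

The compounds below may be only part of what the source reports. "The series", "measured", "known", "first", "only" and "open" are said of these compounds alone.

Compound 1 `COc1ccc(C2=NNC(c3c(Cl)cccc3Cl)C2)cc1OC`: 58%
Compound 2 `COc1ccc(C2=NNC(c3c(Cl)cccc3Cl)C2)cc1`: 60%
Compound 3 `COc1ccc(C2CC(c3ccc(OC)c(OC)c3)=NN2C(=O)CBr)c(OC)c1`: 71%

In a functional assay on the whole organism (strain albino) for inhibition, with Rattus norvegicus as the target, read by paw edema, with stated times of 30 min and 3 h, at a dose of 100 mg/kg by the oral route (a higher number here means more inhibition at the dose given (going by the name of the read-out), a lower number less inhibition), compound 1 holds the lowest of the three numbers, though the step of a number 2 percentage points higher from compound 1 to compound 2 (within the scatter) lies within the scatter; only the number of compound 3 stands beyond it. The unmeasured compound 4 `COc1ccc(C2=NN(C(=O)CBr)C(c3c(Cl)cccc3Cl)C2)cc1OC` differs from compound 1 by (bromomethyl)carbonyl in place of hydrogen on an amine nitrogen in a ring. Among the measured compounds shown here, no measured step follows this exact change on the shared core of compound 1. Compound 3 does carry the same (bromomethyl)carbonyl group on its ring nitrogen and gives the highest number, so a modest rise is expected. The step of a number 10 percentage points higher from compound 1 to compound 4 (within the scatter) is the estimated outcome, giving compound 4 an expected 68% within 58% to 78%.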

Compound 4, a percentage reported as inhibition, in the whole organism at one dose (the size of the read-out at that dose, not a potency): 69%
Estimate against measurement, compound 4: 1 percentage points below, within the range that was stated.
By their numbers in this assay, from the lowest: compounds 1, 2, 4 and 3 (each within the scatter of the next, the first and the last beyond it).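

Within this assay the change gives a number 11 percentage points higher from compound 1 to compound 4 (beyond the scatter) on the shared core, with (bromomethyl)carbonyl in place of hydrogen on the amine nitrogen in the ring. Unlike the step between compound 1 and compound 2, this single change lies beyond the scatter, so this nitrogen is a place where a change registers in the read-out at this dose. Nothing available here accounts for the rise. Going by these compounds, what remains open is whether a plain acetyl group, without bromine, or a longer chain on this nitrogen would give a similar number. On these data alone, it is also open whether the same group would do the same on the core of compound 2.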